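This account rests on a few compounds, and the source may have more. Where it says the series, first, only, none or still open, it means among the compounds named here.

Working notes on the series. The shared core is that of compound 1 `O=C(CCc1ccc(C(F)(F)F)cc1)Nc1ccc2nc(N3CCC3)ccc2c1`, which in a functional assay on HEK293 cells for activation of melanin-concentrating hormone receptor 1 (Rattus norvegicus), read by inositol phosphate accumulation (a lower number here means that less compound is needed, a higher number that more compound is needed for the effect), gives 56 nM. Compound 2 `CC(C)N(C)c1ccc2cc(NC(=O)CCc3ccc(C(F)(F)F)cc3)ccc2n1` in this assay gives 140 nM, and compound 3 `O=C(CCc1ccc(C(F)(F)F)cc1)Nc1ccc2nc(N3CCC(c4ccccc4)C3)ccc2c1` in this assay gives 1770 nM. Compound 3 carries the highest number of the three: the step of a 32-fold higher number from compound 1 to compound 3 (1.50 log units; beyond the scatter) is large, as is the step of a 13-fold higher number from compound 2 to compound 3 (1.10 log units; beyond the scatter), while the step of a 2.5-fold higher number from compound 1 to compound 2 (0.40 log units; beyond the scatter) is modest by comparison.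

The next compound, compound 4 `CC(=O)NC1CCN(c2ccc3cc(NC(=O)CCc4ccc(C(F)(F)F)cc4)ccc3n2)C1`, differs from compound 3 in one place: acetamido in place of phenyl on a saturated ring carbon. Going by the values given here, no measured pair swaps one substituent on that saturated ring for another, so this step has no direct precedent. What bears on it is indirect: the two large steps of a 32-fold higher number from compound 1 to compound 3 (1.50 log units; beyond the scatter) and a 13-fold higher number from compound 2 to compound 3 (1.10 log units; beyond the scatter) are the steps that introduced 3-phenylpyrrolidin-1-yl, and compound 4 gives up the phenyl while keeping the five-membered ring. Part of that loss is therefore expected to be recovered in this assay, but not all of it; the acetamido group has no measured counterpart in the series. Compound 4 is expected to give an estimated 400 nM in this assay, within 100 nM to 1500 nM. The estimated step of a 4.4-fold lower number from compound 3 to compound 4 (0.65 log units; beyond the scatter) would be a moderate lowering.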

Compound 4, half-maximal effective concentration: 440 nM
The estimate for compound 4 lay 1.1-fold (0.04 log units) below the measured number; the range from low to high includes it.
By their numbers in this assay, from the lowest: compound 1; then compound 2; then compound 4; then compound 3.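

In this assay, going by these compounds alone, the step of a 4.0-fold lower number from compound 3 to compound 4 (0.60 log units; beyond the scatter) is the first measured swap of one substituent for another on this saturated ring carbon, two ring bonds from the ring nitrogen. It shows that the number responds to the group at this position and not only to the five-membered ring that carries it. The lowering is only partial: the steps of a 3.1-fold higher number from compound 2 to compound 4 (0.50 log units; beyond the scatter) and a 7.9-fold higher number from compound 1 to compound 4 (0.90 log units; beyond the scatter) leave 3-acetamidopyrrolidin-1-yl still above both isopropyl(methyl)amino and azetidin-1-yl in this series. No measurement shown accounts for the lowering, and what separates phenyl from acetamido in its effect on the number stays unassigned.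

The compounds shown leave open how unsubstituted pyrrolidin-1-yl, or a hydroxyl or primary amine on the same saturated ring carbon, would stand against phenyl and acetamido, so the loss of phenyl and the entry of acetamido cannot yet be told apart. Also open, on these data alone, is whether a hydroxyl or acetamido on the azetidin-1-yl ring would keep the number close to that of compound 1.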